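Swapping propyl for ethynyl on a sulfur

A few compounds are considered here, and "the series" means these few. Any claim that something is new, unique, unknown or untested is made for them only; others in the source may bear on it.

Among the compounds with values here, compound 2 `CCCSc1nc2nc(C)cc(N3CC[C@@H](C)[C@@H](N(C)c4ncnc5[nH]ccc45)C3)n2n1` gives 67100 nM in a toxicity assay on GES1 cells (Homo sapiens) for inhibition, read by MTT assay, with a stated time of 72 h (on this read-out higher numbers stand for weaker inhibition and lower numbers for stronger inhibition), and this is the only exact figure available for the series so far. Compound 1 `Cc1cc(N2CC[C@@H](C)[C@@H](N(C)c3ncnc4[nH]ccc34)C2)n2nc(SCc3ccc(F)c(Cl)c3)nc2n1` gives > 100000 nM in this assay, which is a limit of the assay and not a number.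

Compound 3 `C#CSc1nc2nc(C)cc(N3CC[C@@H](C)[C@@H](N(C)c4ncnc5[nH]ccc45)C3)n2n1` keeps the core of compound 2 and carries ethynyl in place of propyl on a sulfur. Within the data shown here, only one measured step bears on this change, since it also alters the chain on that sulfur: an at least 1.4-fold lower number from compound 1 to compound 2 (0.17 log units; that floor lies within the scatter). That step is only a floor, and the floor stays within the scatter, so it shows no firm shift even for the exchange of a 3-chloro-4-fluorophenyl group for ethyl. With compound 2 at 67100 nM as the starting point, no step beyond the scatter is expected in this assay. The estimated change is a 1.1-fold lower number from compound 2 to compound 3 (0.05 log units; within the scatter). Compound 3 is estimated at 60000 nM, with an expected range from 25000 nM to 100000 nM.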

Compound 3, half-maximal inhibitory concentration: > 100000 nM
Compound 3 gave a limit, no number (the forecaster's own chance of this, stated with the estimate: 25%); middle value at least 1.6-fold (0.22 log units) away from the limit.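

In this assay, within the data shown here, the sulfur now carries a second group that ends at a limit: ethynyl joins the 3-chloro-4-fluorobenzyl group of compound 1, and propyl in compound 2 remains the only one of the three groups with an exact figure. The exchange of propyl for ethynyl gives an at least 1.4-fold higher number from compound 2 to compound 3 (0.17 log units; that floor lies within the scatter), so this small change on the sulfur yields only a floor, and that floor does not separate the two compounds beyond the usual scatter. The step from compound 1 to compound 3 cannot be read, and the limit of the assay sets how little this position can show so far: the limit of > 100000 nM in this assay, at which 2 of the 3 values shown sit.

As far as these compounds go, how far compound 3 actually lies from compound 2 stays open, and so does any ranking of the three groups on the sulfur. Whether any group here can bring the number clearly down from that of compound 2 also remains unanswered, for instance a longer chain such as butyl or a propyl chain ending in an amine.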